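The compounds below may be only part of what the source reports. "The series", "measured", "known", "first", "only" and "open" are said of these compounds alone.

Within the data shown here, compound 2 `CCOC(=O)C1=Cc2ccccc2OC1(OCc1cn(CC(=O)NC2CCCCC2)nn1)C(F)(F)F` gives 11400 nM in a functional assay on HeLa cells (Homo sapiens) for inhibition, read by MTT assay, with a stated time of 24 h (on this read-out higher numbers stand for weaker inhibition and lower numbers for stronger inhibition), the lowest of the two numbers so far; compound 1 `CCOC(=O)C1=Cc2ccccc2OC1(OCc1cn(CC(=O)Nc2ccccc2F)nn1)C(F)(F)F` gives 49900 nM in this assay, and the step of a 4.4-fold lower number from compound 1 to compound 2 (0.64 log units; beyond the scatter) lies beyond the scatter. Compound 3 `CCOC(=O)C1=Cc2ccccc2OC1(OCc1cn(-c2ccc([N+](=O)[O-])cc2)nn1)C(F)(F)F` differs from compound 2 by 4-nitrophenyl in place of (cyclohexylcarbamoyl)methyl on an aromatic nitrogen. Among the measured compounds shown here, no measured step bears on this change: the only step known, a 4.4-fold lower number from compound 1 to compound 2 (0.64 log units; beyond the scatter), concerns cyclohexyl against 2-fluorophenyl on the amide-type nitrogen, and in compound 3 that whole group is gone. For compound 3 in this assay the expected step is a 1.8-fold higher number from compound 2 to compound 3 (0.24 log units; within the scatter), with a wide range. Compound 3 is estimated at 20000 nM, between 5000 nM and 80000 nM.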

Compound 3, half-maximal inhibitory concentration: > 150000 nM
Compound 3 ended at the assay's limit; the forecaster's own chance of this, stated with the estimate: 10%; at least 7.5-fold (0.87 log units) between middle value and limit.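

Compound 3 stands at a limit of the assay, not at a number: the limit of > 150000 nM in this assay, at which 1 of the 3 values shown sits. Until now only the group on the amide-type nitrogen had varied; replacing the whole (cyclohexylcarbamoyl)methyl group on the aromatic nitrogen gives an at least 13-fold higher number from compound 2 to compound 3 (1.11 log units; beyond the scatter). Even against the weaker amide, the change gives an at least 3.0-fold higher number from compound 1 to compound 3 (0.47 log units; beyond the scatter), so both amide-bearing compounds show stronger inhibition than the 4-nitrophenyl compound.

The compounds shown do not separate the departure of the amide from the entry of 4-nitrophenyl. A plain phenyl on this nitrogen would bear on that question.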